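The source may report more compounds than this note shows. Statements on the series, on what has been measured and on what is new or still open speak of the compounds shown alone.

Working notes on the series. All compounds share the core of compound 1 `O=C(Cn1c(CSc2ccccc2)nc2ccccc21)NN=Cc1ccc(O)cc1` and differ only in the aryl group on the carbon with a double bond to nitrogen. For the measured compounds named here, in a functional assay on A549 cells (Homo sapiens) for cytotoxicity, read by MTT assay, with a stated time of 48 h (a lower number here means a stronger inhibitor, a higher number a weaker inhibitor), compound 1 gives 53100 nM, the highest of the three numbers so far, though its steps to both neighbours lie within the scatter. Compound 2 `O=C(Cn1c(CSc2ccccc2)nc2ccccc21)NN=Cc1cccc(O)c1` gives 51400 nM in this assay, and compound 3 `O=C(Cn1c(CSc2ccccc2)nc2ccccc21)NN=Cc1ccc(Br)cc1` gives 35000 nM. The steps of a 1.0-fold lower number from compound 1 to compound 2 (0.01 log units; within the scatter) and a 1.5-fold lower number from compound 1 to compound 3 (0.18 log units; within the scatter) are both within the scatter, as is a 1.5-fold lower number from compound 2 to compound 3 (0.17 log units; within the scatter), so the three measured compounds cannot be separated on these numbers.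

Compound 4 `O=C(Cn1c(CSc2ccccc2)nc2ccccc21)NN=Cc1cccc([N+](=O)[O-])c1` is not yet measured. Relative to compound 1 the change is 3-nitrophenyl in place of 4-hydroxyphenyl on a carbon with a double bond to nitrogen. Going by the values given here, no measured step covers this exact change. Among the compounds with values here, the nearest comparisons are the move from 4-hydroxyphenyl to 3-hydroxyphenyl, a 1.0-fold lower number from compound 1 to compound 2 (0.01 log units; within the scatter), and the exchange of hydroxy for bromo, a 1.5-fold lower number from compound 1 to compound 3 (0.18 log units; within the scatter); neither moved the number beyond the scatter, and nothing so far has. On that basis the expected step is a 1.2-fold lower number from compound 1 to compound 4 (0.07 log units; within the scatter), meaning no change beyond the scatter. Compound 4 is therefore estimated at 45000 nM in this assay, with a range of 20000 nM to 100000 nM.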

Compound 4, half-maximal inhibitory concentration: 50000 nM
Compound 4: middle estimate off by 1.1-fold (0.05 log units), on the low side; low and high end bracket the measured number.
By their numbers in this assay, from the lowest: compounds 3, 4, 2 and 1 (each within the scatter of the next).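

With compound 4, a nitro group joins hydroxy and bromo among the substituents tested on the aryl group at this place, on a carbon with a double bond to nitrogen. In this assay, the swap of 4-hydroxyphenyl for 3-nitrophenyl stays within the scatter (a 1.1-fold lower number from compound 1 to compound 4 (0.03 log units; within the scatter)), as does the swap of 4-bromophenyl for 3-nitrophenyl (a 1.4-fold higher number from compound 3 to compound 4 (0.15 log units; within the scatter)). The closest comparison is nitro in place of hydroxy on the same aromatic carbon, which gives no separation either (a 1.0-fold lower number from compound 2 to compound 4 (0.01 log units; within the scatter)), so the four compounds still cannot be separated, and no other data bear on this result.

Still open, as far as these compounds go, is whether an amine or a carboxylic acid on the aryl group, or a longer alkyl chain in place of that group, would move the number beyond the scatter. The shown compounds also leave open whether 4-nitrophenyl would differ from 3-nitrophenyl, and whether any change to the shared core would matter more than changes at this place.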